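The source may report more compounds than this note shows. Statements on the series, on what has been measured and on what is new or still open speak of the compounds shown alone.

Compound 1 `O=C(/C=C/c1coc2cc(O)ccc2c1=O)NCc1ccc(F)cc1` is measured in a functional assay on Huh-7 cells (Homo sapiens) for inhibition, read by MTT assay, with a stated time of 48 h (on this read-out higher numbers stand for weaker inhibition and lower numbers for stronger inhibition), where compound 1 gives > 100000 nM, a limit of the assay rather than a number. Compound 2 `COc1ccc(NC(=O)/C=C/c2coc3cc(O)ccc3c2=O)cc1` in this assay gives > 100000 nM, likewise a limit. The step between them reads as a step that the two limits leave unreadable from compound 1 to compound 2, both values sitting at the limit of > 100000 nM in this assay, at which 2 of the 2 values shown sit. Compound 3 `O=C(/C=C/c1coc2cc(O)ccc2c1=O)NCc1ccc(F)cc1F` differs from compound 1 by fluoro in place of hydrogen on an aromatic carbon. Within the data shown here, no measured step reads on this change, and compound 1 itself stands only at a limit. Compound 3 is expected to stay at that limit, an estimated 100000 nM (range 30000 nM to 300000 nM), which means an expected step of a number no higher from compound 1 to compound 3 (the limit leaves the size open).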

Compound 3, half-maximal inhibitory concentration: > 100000 nM
Compound 3: no number, only a limit (the forecaster's own chance of this, stated with the estimate: 80%); the middle value lies on the limit itself.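

Compound 1 and compound 3 both stand only at a limit, not at a number, so no step between them can be read: the limit of > 100000 nM in this assay, at which 3 of the 3 values shown sit.

The compounds shown leave open whether fluoro in place of hydrogen changes inhibition at all, and how they rank against one another.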